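This account rests on a few compounds, and the source may have more. Where it says the series, first, only, none or still open, it means among the compounds named here.

Measured compounds: compound 1 `CCOc1ccc(NC(=O)N/N=C/c2ccccc2Cl)cc1` gives 100 mg/kg; compound 2 `CCOc1ccc(NC(=O)N/N=C/c2ccccc2O)cc1` gives 300 mg/kg; compound 3 `CCOc1ccc(NC(=O)N/N=C(\C)c2ccc(O)cc2)cc1` gives 100 mg/kg, all in a functional assay on the whole organism with Mus musculus as the target, in the maximal electroshock model, with a stated time of 0.5 h; a higher number here means that more compound is needed for the effect, a lower number that less compound is needed.

The step from compound 2 to compound 1 is chloro in place of hydroxy on an aromatic carbon, and it brought a 3.0-fold lower number from compound 2 to compound 1 (0.48 log units; beyond the scatter). Compound 3 shares the same change with the unmeasured compound 4 `CCOc1ccc(NC(=O)N/N=C(\C)c2ccc(Cl)cc2)cc1`: chloro in place of hydroxy on an aromatic carbon. The place differs, however: in compound 2 the group sits ortho to a large group, in compound 3 para to a large group, so it is the same kind of change, not the same. How the core of compound 3 differs from that of compound 2 is not broken down here. Compound 3 stands level with compound 1, together the lowest of the three numbers. The estimated step of a 1.7-fold lower number from compound 3 to compound 4 (0.22 log units; within the scatter) is expected to be somewhat smaller than the earlier one, because it rests on a 3.0-fold lower number from compound 2 to compound 1 (0.48 log units; beyond the scatter) alone. Compound 4 is expected to give 60 mg/kg in this assay.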

Compound 4, minimum effective dose: 300 mg/kg
The estimate for compound 4 lay 5.0-fold (0.70 log units) below the measured number, and the stated range ends below it.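

Exchanging hydroxy for chloro in the 4-hydroxyphenyl group brought a 3.0-fold higher number from compound 3 to compound 4 (0.48 log units; beyond the scatter) in this assay, and set beside the earlier step, the same change ran in opposite directions on the two cores: the same change on two cores in this assay, a 3.0-fold lower number (0.48 log units; beyond the scatter) from compound 2 to compound 1 and a 3.0-fold higher number (0.48 log units; beyond the scatter) from compound 3 to compound 4, 9.0-fold (0.95 log units) apart, beyond the scatter of two such steps
So, in this series, the result of this change on one core did not predict its result on the other. This does not show what lies behind the reversal, since the two pairs differ both in their core and in where the group sits, and a single pair of each cannot separate the two.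

The compounds shown leave open how an amine or a methoxy group in the same place on the core of compound 3 would compare. They also leave open whether the step would keep its direction with hydroxy and chloro moved elsewhere on that core.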